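This account rests on a few compounds, and the source may have more. Where it says the series, first, only, none or still open, it means among the compounds named here.

Measured in a functional assay on HT-1080 cells (Homo sapiens) for cytotoxicity, read by MTT assay, with a stated time of 72 h; on this read-out lower numbers stand for stronger inhibition and higher numbers for weaker inhibition:
- compound 1 `COc1cccc(/C=C2\CCC/C(=C\c3cccc(OC)c3OC)C2=O)c1`: 9900 nM
- compound 2 `COc1ccc(/C=C2\CCC/C(=C\c3cccc(OC)c3OC)C2=O)cc1`: 16300 nM
- compound 3 `COc1cccc(/C=C2\CCC/C(=C\c3ccc(Cl)c(Cl)c3)C2=O)c1OC`: 10800 nM

Compound 2, at 16300 nM, lies within the scatter of both other compounds, so the three cannot be ranked. Compound 4 `COc1ccc(/C=C2\CCC/C(=C\c3cccc(OC)c3OC)C2=O)cc1OC` differs from compound 2 by one change, (methoxy in place of hydrogen on an aromatic carbon), that is, methoxy in place of hydrogen on an aromatic carbon. Going by the values given here, no measured step makes exactly this addition. The nearest evidence comes from exchanges of the same aromatic group. Replacing 4-methoxyphenyl with 3,4-dichlorophenyl gave a 1.5-fold lower number from compound 2 to compound 3 (0.18 log units; within the scatter). Replacing 3-methoxyphenyl with 4-methoxyphenyl gave a 1.6-fold higher number from compound 1 to compound 2 (0.22 log units; within the scatter), and replacing it with 3,4-dichlorophenyl gave a 1.1-fold higher number from compound 1 to compound 3 (0.04 log units; within the scatter). All three steps stay within the scatter, so no step beyond the scatter is expected in this assay, and no direction can be firmly expected. The expected step is a 1.4-fold lower number from compound 2 to compound 4 (0.13 log units; within the scatter). For compound 4 the estimated value is 12000 nM, with an expected range of 6000 nM to 24000 nM.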

Compound 4, half-maximal inhibitory concentration: 6400 nM
Compound 4: the middle estimate sits 1.9-fold (0.27 log units) above what was measured, within the range that was stated.
By their numbers in this assay, from the lowest: compounds 4, 1, 3 and 2 (each within the scatter of the next, the first and the last beyond it).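

In this assay, methoxy in place of hydrogen on an aromatic carbon, ortho to a methoxy group and meta to a large group, gave a 2.5-fold lower number from compound 2 to compound 4 (0.41 log units; beyond the scatter). Going by these compounds alone, this is the first modest step beyond the scatter, as the exchanges among the earlier compounds all stayed within it. The same kind of addition read from the other neighbour gave a 1.5-fold lower number from compound 1 to compound 4 (0.19 log units; within the scatter), so the effect appears on only one of the two routes to compound 4, and nothing measured here accounts for the step.

The compounds shown leave open whether an ethoxy group, a hydroxy group or an amine on this aromatic carbon would give a similar step. They also leave open whether the step would hold with a different group on the second aromatic ring.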